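The compounds below may be only part of what the source reports. "The series", "measured", "known", "first", "only" and "open" are said of these compounds alone.

Compound 1, `COCNc1n[n+]([O-])c2ccccc2[n+]1[O-]`, gives 7800 nM in a functional assay on K562 cells (Homo sapiens) for cytotoxicity, read by MTT assay, with a stated time of 72 h; on this read-out lower numbers stand for stronger inhibition and higher numbers for weaker inhibition.
Compound 2, `CCCCCOCNc1n[n+]([O-])c2ccccc2[n+]1[O-]`, gives 14500 nM in this assay.
Compound 3, `[O-][n+]1nc(NCOCc2ccccc2)[n+]([O-])c2ccccc21`, gives 16100 nM in this assay.

Compound 3 holds the highest of the three numbers. Its nearest neighbour is compound 2, with a 1.1-fold higher number from compound 2 to compound 3 (0.05 log units; within the scatter), and its furthest is compound 1, with a 2.1-fold higher number from compound 1 to compound 3 (0.31 log units; beyond the scatter). Compound 4, `[O-][n+]1nc(NCOCc2ccc(Cl)cc2)[n+]([O-])c2ccccc21`, differs from compound 3 by chloro in place of hydrogen on an aromatic carbon.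

Going by the values given here, none of the measured steps alters an aromatic carbon; all three concern the saturated chain carbon bound to an oxygen. There, a 1.9-fold higher number from compound 1 to compound 2 (0.27 log units; within the scatter) and a 1.1-fold higher number from compound 2 to compound 3 (0.05 log units; within the scatter) show that replacing one group with another at that carbon moves the number little, and only a 2.1-fold higher number from compound 1 to compound 3 (0.31 log units; beyond the scatter) reaches modestly beyond the scatter. Among the compounds with values here, no measured step therefore bears directly on the change to compound 4, and the observed variation argues for a small step in this assay, with no direction that can be supported. Compound 4 is expected to show a 1.2-fold lower number from compound 3 to compound 4 (0.06 log units; within the scatter). The estimate for compound 4 in this assay is 14000 nM, within a range from 6000 nM to 35000 nM.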

Compound 4, half-maximal inhibitory concentration: 3260 nM
Estimate against measurement, compound 4: 4.3-fold (0.63 log units) above; measured number below the stated range.
By their numbers in this assay, from the lowest: compound 4; then compounds 1, 2 and 3 (each within the scatter of the next, the first and the last beyond it).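

Going by these compounds alone, the change on the aromatic carbon, para to a large group, is the first to move the number well beyond the scatter: chloro in place of hydrogen gives a 4.9-fold lower number from compound 3 to compound 4 (0.69 log units; beyond the scatter) in this assay, a larger step than any seen at the saturated chain carbon. It also reverses the direction seen with phenyl at that chain carbon, since 4-chlorophenyl gives a 2.4-fold lower number from compound 1 to compound 4 (0.38 log units; beyond the scatter) in place of hydrogen and a 4.4-fold lower number from compound 2 to compound 4 (0.65 log units; beyond the scatter) in place of butyl. Nothing available explains why this one chlorine has so large an effect.

The compounds shown leave open whether bromo, fluoro or methoxy on the same aromatic carbon would lower the number as chloro does. They also leave open what chloro would do on any other carbon of the phenyl ring.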